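The source may hold more compounds than are shown below. What is called first, only, known or untested is meant among the compounds shown, and "the series" means these compounds.

Measured compounds:
Compound 1 `CCCSc1nc(N/N=C/c2ccccc2Cl)c2nnn(Cc3ccccc3)c2n1` gives 10900 nM in a functional assay on MGC-803 cells (Homo sapiens) for antiproliferative activity, read by MTT assay, with a stated time of 72 h; a lower number here means a stronger inhibitor, a higher number a weaker inhibitor.
Compound 2 `CCCSc1nc(N/N=C/c2ccc([N+](=O)[O-])cc2)c2nnn(Cc3ccccc3)c2n1` gives 10100 nM in this assay.

Compound 2 stands alongside compound 1 on the two numbers shown, since the step of a 1.1-fold lower number from compound 1 to compound 2 (0.03 log units; within the scatter) lies within the scatter; the two values cannot be told apart. Compound 3 `CCCSc1nc(N/N=C/c2cccc(Cl)c2)c2nnn(Cc3ccccc3)c2n1` has not yet been measured. It differs from compound 2 in one place: 3-chlorophenyl in place of 4-nitrophenyl on a carbon with a double bond to nitrogen. Going by the values given here, the only measured step that bears on this change is the exchange of the aryl group on the carbon with a double bond to nitrogen, a 1.1-fold lower number from compound 1 to compound 2 (0.03 log units; within the scatter), which left the number essentially where it was. Among the compounds with values here, with a further aryl exchange at the same place and no measured step showing a shift beyond the scatter, compound 3 is expected to change little, so a 1.0-fold higher number from compound 2 to compound 3 (0.02 log units; within the scatter) is estimated to stay within the scatter. Compound 3 is therefore estimated at 10500 nM, with a range from 5000 nM to 22000 nM.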

Compound 3, half-maximal inhibitory concentration: > 64000 nM
Compound 3: a limit, no number; the forecaster's own chance of this, stated with the estimate: 5%; at least 6.0-fold (0.78 log units) between middle value and limit.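

The aryl group on the carbon with a double bond to nitrogen proves far less forgiving than the earlier pair suggested: in this assay there is an at least 6.3-fold higher number from compound 2 to compound 3 (0.80 log units; beyond the scatter). The step from the 2-chlorophenyl compound is of similar standing, with an at least 5.8-fold higher number from compound 1 to compound 3 (0.76 log units; beyond the scatter), and there the group keeps its chlorine and only the name changes from 2-chlorophenyl to 3-chlorophenyl, so the place of the chlorine on the ring matters in this series. Compound 3 gives a limit of the assay, not a number: the limit of > 64000 nM in this assay, at which 1 of the 3 values shown sits.

Going by these compounds, how far compound 3 lies from the other two remains unknown. On these data alone, it also remains open whether 3-nitrophenyl, 4-chlorophenyl or 3-aminophenyl at this place would give numbers like those of compound 1 and compound 2 or a limit like that of compound 3.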